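Swapping nitro for methyl on a chalcone amide

The compounds below may be only part of what the source reports. "The series", "measured", "known", "first", "only" and "open" are said of these compounds alone.

Compound 1 `Cc1cccc(NC(=O)CSC(=S)N[C@H]2CCOC2=O)c1`: 63200 nM
Compound 2 `O=C(CSC(=S)N[C@H]1CCOC1=O)Nc1cccc([N+](=O)[O-])c1`: 5460 nM
Compound 3 `O=C(CCl)Nc1ccc(C(=O)/C=C/c2ccc([N+](=O)[O-])cc2)cc1`: 3910 nM

All three were tested in a functional assay on MCF7 cells (Homo sapiens) for cytotoxicity, read by MTT assay, with a stated time of 72 h; on this read-out higher numbers stand for weaker inhibition and lower numbers for stronger inhibition. Compound 1 differs from compound 2 by methyl in place of nitro on an aromatic carbon, and that change gave a 12-fold higher number from compound 2 to compound 1 (1.06 log units; beyond the scatter). Compound 3 and compound 2 share no single point of difference; the difference between the two cores is not broken down here. Compound 4 `Cc1ccc(/C=C/C(=O)c2ccc(NC(=O)CCl)cc2)cc1` has not yet been measured; it differs from compound 3 by methyl in place of nitro on an aromatic carbon. This is the same kind of change as from compound 2 to compound 1, though there the group sits meta to a large group and here para to a large group. Compound 4 is expected to show a 3.8-fold higher number from compound 3 to compound 4 (0.58 log units; beyond the scatter) in this assay, a smaller step than the earlier one, because the earlier move gave a 12-fold higher number from compound 2 to compound 1 (1.06 log units; beyond the scatter) on a different core. Compound 4 is thus estimated at 15000 nM, between 5000 nM and 60000 nM.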

Compound 4, half-maximal inhibitory concentration: 9180 nM
Compound 4: middle estimate off by 1.6-fold (0.21 log units), on the high side; the measured number falls inside the stated range.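

In this assay, methyl in place of nitro again weakened inhibition, giving a 2.3-fold higher number from compound 3 to compound 4 (0.37 log units; beyond the scatter), so the direction of the change held on both cores. The size of the step did not carry over from one core to the other: the same change on two cores in this assay, a 12-fold higher number (1.06 log units; beyond the scatter) from compound 2 to compound 1 and a 2.3-fold higher number (0.37 log units; beyond the scatter) from compound 3 to compound 4, 4.9-fold (0.69 log units) apart, beyond the scatter of two such steps These two pairs do not show why the sizes differ, since the cores differ and the group's place on the ring differs too, so the size of this change on a further core cannot be read from them.

The compounds shown leave open how an amine or a carboxylic acid in the same place would compare with nitro and methyl on either core. They also leave open whether the two cores would match if the group stood in the same place on both.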